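Methyl for tert-butyl on a fused-ring urea

The source may hold more compounds than are shown below. What is called first, only, known or untested is meant among the compounds shown, and "the series" means these compounds.

Measured so far:
compound 1, `O=C(Nc1cccc2[nH]ncc12)NC1CCc2ncccc21`, 5820 nM
compound 2, `CC(C)(C)c1cccc2c1CCC2NC(=O)Nc1cccc2[nH]ncc12`, 14 nM
compound 3, `COc1ccc2c(c1)CCC2NC(=O)Nc1cccc2[nH]ncc12`, 40 nM

Three ureas built on the same core have been tested in an assay on isolated protein for inhibition of transient receptor potential cation channel subfamily V member 1 (Homo sapiens), read by calcium flux; a lower number here means a stronger inhibitor, a higher number a weaker inhibitor. Compound 1 gives 5820 nM, compound 3 gives 40 nM, and compound 2 gives 14 nM. Compound 2 stands lowest of the three, and its separation from each of the other two lies beyond the usual scatter, so it is the strongest inhibitor among them.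

The next compound, compound 4 with structure `Cc1cccc2c1CCC2NC(=O)Nc1cccc2[nH]ncc12`, has not yet been measured. It differs from compound 2 in one place: methyl in place of tert-butyl on an aromatic carbon. For the measured compounds named here, no measured pair shows this exact exchange, so the size of the step can only be guessed. Since compound 2 with its tert-butyl gives 14 nM while the unsubstituted compound 1 gives 5820 nM, a smaller group is expected to lose some potency, and the step of a 7.1-fold higher number from compound 2 to compound 4 (0.85 log units; beyond the scatter) is expected to be a moderate weakening beyond the scatter. Compound 4 is therefore estimated at 100 nM, within a range of 30 nM to 400 nM.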

Compound 4, half-maximal inhibitory concentration: 46 nM
Compound 4: the middle estimate sits 2.2-fold (0.34 log units) above what was measured; the measured number falls inside the stated range.
By their numbers in this assay, from the lowest: compound 2; then compounds 3 and 4 (each within the scatter of the next); then compound 1.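

In this assay, the exchange gives a direct reading of a single change at this aromatic carbon, ortho to a fused ring: a 3.3-fold higher number from compound 2 to compound 4 (0.52 log units; beyond the scatter). The step lies beyond the usual scatter, so the choice of group here registers in the assay, yet the change is modest for a drop from 4 heavy atoms to 1, with neither group carrying hydrogen-bond donors, acceptors or charge. Nothing shown explains why the number rises.

For the compounds shown here, with only two groups compared at this carbon, it remains open whether ethyl or isopropyl would fall between them, or whether the trend is smooth at all. On these data alone, it is also open what a bare hydrogen, an amine or a carboxylic acid would give at the same place on the shared core.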